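Working notes: 4-methylphenyl to phenyl in compound 4

A few compounds are considered here, and "the series" means these few. Any claim that something is new, unique, unknown or untested is made for them only; others in the source may bear on it.

Measured so far in a functional assay on MCF7 cells (Homo sapiens) for cytotoxicity, read by sulforhodamine B assay, with a stated time of 24 h; on this read-out higher numbers stand for weaker inhibition and lower numbers for stronger inhibition
compound 1 `COc1ccc(-c2c(C#N)c(N)n(/N=C3\C(=O)Nc4ccc(S(=O)(=O)N5CCOCC5)cc43)c(=O)c2C#N)cc1`: 33400 nM
compound 2 `Cc1ccc(S(=O)(=O)N/N=C2\C(=O)Nc3ccc(S(=O)(=O)N4CCOCC4)cc32)cc1`: 38400 nM
compound 3 `O=C1Nc2ccc(S(=O)(=O)N3CCOCC3)cc2/C1=N/c1ccc(/N=C2\C(=O)Nc3ccc(S(=O)(=O)N4CCOCC4)cc32)cc1`: 10900 nM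

Compound 2 gives 38400 nM and lies within the scatter of compound 1 at 33400 nM on this read-out. Compound 3 gives 10900 nM in the same measurements. Against compound 2, compound 3 stands lower, beyond the scatter.

The next step is small. The change hydrogen in place of methyl on an aromatic carbon turns 4-methylphenyl into phenyl: hydrogen in place of methyl on an aromatic carbon, para to a large group, gives compound 4 `O=C1Nc2ccc(S(=O)(=O)N3CCOCC3)cc2/C1=N/NS(=O)(=O)c1ccccc1` from compound 2.

Among the compounds with values here, no two measured compounds differ in one place only, so the data show no size for this change. In this assay no step beyond the scatter is expected, in either direction. This expectation rests only on compound 2 at 38400 nM and on the small structural difference. The estimated step is a 1.1-fold lower number from compound 2 to compound 4 (0.04 log units; within the scatter) and is expected to stay within the scatter. For compound 4 the estimated value is 35000 nM with an expected range from 15000 nM to 70000 nM on this read-out.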

Compound 4, half-maximal inhibitory concentration: 25300 nM
The estimate for compound 4 lay 1.4-fold (0.14 log units) above the measured number; low and high end bracket the measured number.
By their numbers in this assay, from the lowest: compound 3; then compounds 4, 1 and 2 (each within the scatter of the next).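

In this assay the series now has its first pair differing in one place, and it gives (a 1.5-fold lower number from compound 2 to compound 4 (0.18 log units; within the scatter)). Hydrogen in place of methyl on this aromatic carbon therefore leaves the number within the scatter, so on this one pair the methyl of the 4-methylphenyl group makes no readable difference to the read-out. No measurement at hand bears on the reason for this result.

Only methyl and hydrogen are shown at this position, so it stays open whether an amine, a carboxylic acid or a longer chain placed there would carry the number beyond the scatter. A single pair also cannot tell whether the same change would behave alike on another part of the series.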